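Acetylphenyl for Pyridyl on an Imide Core

This account rests on a few compounds, and the source may have more. Where it says the series, first, only, none or still open, it means among the compounds named here.

The study measures an assay on FRT-Jurkat cells for inhibition of nuclear factor NF-kappa-B complex (Homo sapiens), read by flow cytometry, with a stated time of 24 h, tested at 10 uM; on this read-out lower numbers stand for less inhibition and higher numbers for more inhibition at the one concentration tested (going by the name of the read-out). Compound 1 `O=C1CCC(N2C(=O)c3cccc(Nc4ccccn4)c3C2=O)C(=O)N1` gives 1% in this assay, the lowest of the two numbers recorded; compound 2 `CCc1ccc(Nc2ccc3c(c2)C(=O)N(C2CCC(=O)NC2=O)C3=O)cc1` gives 5% in this assay, a figure within the scatter of that of compound 1, so the two cannot be told apart. Both compounds thus show little inhibition at the single concentration used.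

Compound 3 `CC(=O)c1ccc(Nc2cccc3c2C(=O)N(C2CCC(=O)NC2=O)C3=O)cc1` has not yet been tested in this assay. It differs from compound 1 by 4-acetylphenyl in place of pyridin-2-yl on a nitrogen on an aromatic ring. For the measured compounds named here, no step between measured compounds is available to calibrate this change. Going by the values given here, the only guidance is that compound 2, which also carries a substituted phenyl on the same nitrogen, gives 5% in this assay, a number within the scatter of compound 1.

Compound 3 is therefore expected to remain near the scatter, with a step of a number 4 percentage points higher from compound 1 to compound 3 (within the scatter) estimated, that is, no change beyond the usual spread. The value of compound 3 in this assay is estimated at 5%, with a range from -5% to 15%.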

Compound 3, a percentage reported as inhibition, at one concentration (the size of the read-out at that concentration, not a potency): 2%
Estimate against measurement, compound 3: 3 percentage points above; the range from low to high includes it.
By their numbers in this assay, from the lowest: compounds 1, 3 and 2 (each within the scatter of the next).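

At this position, on a nitrogen on an aromatic ring, the change from pyridin-2-yl to 4-acetylphenyl now has a measured size: in this assay the step is a number 1 percentage points higher from compound 1 to compound 3 (within the scatter) and so cannot be told from repeated measurement. For this one pair, then, replacing the ring with one hetero atom by a ring of carbon only and adding the acetyl group leaves the read-out where it was, with little inhibition at the single concentration tested, and the larger group does not move the number beyond the scatter. No measured evidence bears on why this step is so small.

From the compounds shown here alone, what remains open is whether any group on this nitrogen can raise inhibition beyond the scatter, for example a phenyl ring carrying a carboxylic acid or a piperidine in place of the acetyl, or a longer chain in place of the ring. Also open, going by these compounds, is whether compound 1 and compound 3 would still be indistinguishable at a concentration other than the one used here.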